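Acetamido in place of acetoxy

The compounds below may be only part of what the source reports. "The series", "measured", "known", "first", "only" and "open" are said of these compounds alone.

- compound 1 `CC(C)(C)C(=O)OCC1(CO)C/C(=C\CCCCCCCCCCCO)C(=O)O1`: 2.49 ug/mL
- compound 2 `CC(=O)OCCCCCCCCCCCCCCC/C=C1\CC(CO)(COC(=O)C(C)(C)C)OC1=O`: 2.1 ug/mL

Both values come from a functional assay on COLO 205 cells (Homo sapiens) for antiproliferative activity; a higher number here means a weaker inhibitor of growth, a lower number a stronger inhibitor of growth. Among the compounds with values here, compound 2 has only one measured neighbour, and the two numbers cannot be told apart: a 1.2-fold lower number from compound 1 to compound 2 (0.07 log units; within the scatter).

Compound 3 `CC(=O)NCCCCCCCCCCCCCCC/C=C1\CC(CO)(COC(=O)C(C)(C)C)OC1=O` keeps the shared core and differs from compound 2 in one place: acetamido in place of acetoxy on a saturated chain carbon, ten or more bonds along the chain from a double-bonded chain carbon. This exact exchange has not been measured. Within the data shown here, the only measured step that bears on it was made at that same place, with 4-acetoxybutyl in place of hydroxy: a 1.2-fold lower number from compound 1 to compound 2 (0.07 log units; within the scatter). It stayed within the scatter, but a single step of a different kind is thin guidance, so the range is kept wide.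

In this assay no step beyond the scatter is expected, in either direction, and the estimated size is a 1.0-fold higher number from compound 2 to compound 3 (0.02 log units; within the scatter). Compound 3 is estimated at 2.2 ug/mL, with an expected range of 1 ug/mL to 5 ug/mL.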

Compound 3, concentration for 50% growth inhibition: 4.74 ug/mL
For compound 3 the middle estimate is 2.2-fold (0.33 log units) below the measured one, within the range that was stated.
By their numbers in this assay, from the lowest: compounds 2, 1 and 3 (each within the scatter of the next, the first and the last beyond it).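

In this assay, within the data shown here, the far end of the chain does not tolerate every change equally: acetamido in place of acetoxy, which puts a nitrogen and a hydrogen-bond donor where an oxygen stood, gives a 2.3-fold higher number from compound 2 to compound 3 (0.35 log units; beyond the scatter) and so is the first step here to pass the scatter, though only modestly. Set against the hydroxy of compound 1, the 4-acetamidobutyl change gives a 1.9-fold higher number from compound 1 to compound 3 (0.28 log units; within the scatter) and stays within the scatter, so the clear separation holds only between the acetoxy and acetamido ends. Nothing measured here accounts for that separation.

Whether the amide hydrogen matters could be tested with a methylated amide nitrogen, which the compounds shown do not include. As far as these compounds go, how a free amine, a carboxylic acid or a longer chain would fare at this place also remains open.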